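Aryl ether variation on the shared core

This account rests on a few compounds, and the source may have more. Where it says the series, first, only, none or still open, it means among the compounds named here.

In a functional assay on the whole organism (strain Sprague-Dawley) for inhibition, with Rattus norvegicus as the target, with a stated time of 10 min (on this read-out lower numbers stand for an effect already at smaller amounts and higher numbers for an effect only at larger amounts of compound), compound 1 `O=C(O)c1cnc(-c2ccccc2Cl)[nH]c1=O` gives 5 mg/kg. Compound 2 `CCOc1ccccc1-c1ncc(C(=O)O)c(=O)[nH]1` gives 0.5 mg/kg, and compound 3 `CCC(C)Oc1ccccc1-c1ncc(C(=O)O)c(=O)[nH]1` gives 0.5 mg/kg. The steps of a 10-fold lower number from compound 1 to compound 2 (1.00 log units; beyond the scatter) and a 10-fold lower number from compound 1 to compound 3 (1.00 log units; beyond the scatter) both lowered the number, whereas no change at the digits printed from compound 2 to compound 3 (within the scatter). Compound 2 thus stands level with compound 3 at the digits shown, the two together the lowest of the three numbers, with compound 1 furthest away.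

Compound 4 `O=C(O)c1cnc(-c2ccccc2OCc2ccccc2)[nH]c1=O` differs from compound 2 by phenyl in place of methyl on a saturated chain carbon bound to an oxygen on an aromatic ring. For the measured compounds named here, the one step bearing on this place is no change at the digits printed from compound 2 to compound 3 (within the scatter), which left the number unchanged; no measured step introduces a ring there. For compound 4 the expected step is therefore no change at the digits printed from compound 2 to compound 4 (within the scatter), nothing beyond the scatter. Compound 4 is estimated at 0.5 mg/kg, with a range from 0.15 mg/kg to 1.6 mg/kg.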

Compound 4, dose for 50% inhibition: 5 mg/kg
For compound 4 the middle estimate is 10-fold (1.00 log units) below the measured one; measured number above the stated range.
By their numbers in this assay, from the lowest: compounds 2 and 3 (each within the scatter of the next); then compounds 1 and 4 (each within the scatter of the next).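

Readings in this assay show that this position does not accept every added group: benzyloxy comes with a 10-fold higher number from compound 2 to compound 4 (1.00 log units; beyond the scatter) and a 10-fold higher number from compound 3 to compound 4 (1.00 log units; beyond the scatter) while the ethyl step left the number unchanged. Benzyloxy in place of chloro shows no change at the digits printed from compound 1 to compound 4 (within the scatter) so an aryl ether as such does not keep the lower number. No measurement at hand explains this result.

On these data alone, whether the higher number goes with the aromatic ring or with the size of the group stays open. A cyclohexylmethyl or a longer chain such as hexyl in place of benzyl would bear on that.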